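Swapping trifluoromethyl for trifluoromethoxy on a shared core

The source may report more compounds than this note shows. Statements on the series, on what has been measured and on what is new or still open speak of the compounds shown alone.

Compound 1 `Cc1ccc2nc(-c3ccccc3C(F)(F)F)[nH]c(=O)c2c1` was tested in an assay on isolated protein for inhibition of DNA topoisomerase 1 (Homo sapiens), with a stated time of 30 min, tested at 100 uM (on this read-out higher numbers stand for a stronger effect at the one concentration tested and lower numbers for a weaker effect), where compound 1 gives 72%. Its companion compound 2 `Cc1ccc2c(=O)[nH]c(-c3cccc(F)c3)nc2c1` gives 77.5% in this assay, a number within the scatter of that of compound 1, so the two stand side by side. Compound 3 `Cc1ccc2nc(-c3ccccc3OC(F)(F)F)[nH]c(=O)c2c1` has not yet been measured. It differs from compound 1 by trifluoromethoxy in place of trifluoromethyl on an aromatic carbon. Within the data shown here, with no comparable step measured, the expected change from compound 1 to compound 3 is a number 2 percentage points lower from compound 1 to compound 3 (within the scatter), which would not reach beyond the scatter. Compound 3 is therefore estimated at 70%, with a likely range from 45% to 90%.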

Compound 3, a percentage reported as inhibition, at one concentration (the size of the read-out at that concentration, not a potency): 66.9%
Beside the measured number, compound 3's estimate is 3.1 percentage points above it; measured number inside the range.
By their numbers in this assay, from the lowest: compounds 3, 1 and 2 (each within the scatter of the next, the first and the last beyond it).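

In this assay, trifluoromethoxy in place of trifluoromethyl on an aromatic carbon, ortho to a large group, gives a number 5.1 percentage points lower from compound 1 to compound 3 (within the scatter). This position therefore accepts the extra oxygen of trifluoromethoxy with no change that can be told from the scatter of repeated measurements. No measurement on hand offers an explanation for this result.

As far as these compounds go, whether an amine, a carboxylic acid or a longer chain such as butoxy on this same carbon would keep the read-out stays open. From the compounds shown here alone, each compound also has a read-out at only one concentration, so their potencies remain unknown.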